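From thiadiazole to benzimidazole on the sulfur

The compounds below may be only part of what the source reports. "The series", "measured", "known", "first", "only" and "open" are said of these compounds alone.

Within the data shown here, in a functional assay on PC-3 cells (Homo sapiens) for antiproliferative activity, read by MTT assay, with a stated time of 48 h (on this read-out lower numbers stand for stronger inhibition and higher numbers for weaker inhibition), compound 3 (`COc1ccc(CN(C(=O)CSc2nncs2)c2cc(OC)c(OC)c(OC)c2)cc1`) gives 5530 nM, the lowest of the three numbers measured so far. Compound 1 (`COc1ccc(CN(C(=O)CSc2nc3ccc(OC)cc3s2)c2cc(OC)c(OC)c(OC)c2)cc1`) gives 20200 nM, and compound 2 (`COc1ccc(CN(C(=O)CCCSc2nc3ccccc3o2)c2cc(OC)c(OC)c(OC)c2)cc1`) gives 32700 nM. The unmeasured compound 4 (`COc1ccc(CN(C(=O)CSc2nc3ccccc3[nH]2)c2cc(OC)c(OC)c(OC)c2)cc1`) carries 1H-benzimidazol-2-yl in place of 1,3,4-thiadiazol-2-yl on a sulfur.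

The closest evidence is a 3.7-fold lower number from compound 1 to compound 3 (0.56 log units; beyond the scatter), where 1,3,4-thiadiazol-2-yl replaces 6-methoxy-1,3-benzothiazol-2-yl on a sulfur. A second step, a 5.9-fold lower number from compound 2 to compound 3 (0.77 log units; beyond the scatter), runs the same way but also alters the chain. The third, a 1.6-fold higher number from compound 1 to compound 2 (0.21 log units; within the scatter), separates the two compounds with two-ring groups by no more than the scatter. Neither of those compounds carries 1H-benzimidazol-2-yl, so they offer only an indirect guide. Read in reverse, the first two steps suggest a move to a higher number in this assay, of similar size, and the expected step is a 2.5-fold higher number from compound 3 to compound 4 (0.40 log units; beyond the scatter). Compound 4 is estimated at 14000 nM, with an expected range from 5000 nM to 35000 nM.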

Compound 4, half-maximal inhibitory concentration: 14400 nM
For compound 4 the middle estimate is 1.0-fold (0.01 log units) below the measured one, within the range that was stated.
By their numbers in this assay, from the lowest: compound 3; then compounds 4, 1 and 2 (each within the scatter of the next, the first and the last beyond it).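

In this assay, a 2.6-fold higher number from compound 3 to compound 4 (0.42 log units; beyond the scatter) shows that a second two-ring group on this sulfur also gives a higher number than the single-ring 1,3,4-thiadiazol-2-yl, so compound 3 stays the lowest of the four. The two-ring groups themselves are not separated: a 1.4-fold lower number from compound 1 to compound 4 (0.15 log units; within the scatter) leaves 1H-benzimidazol-2-yl and 6-methoxy-1,3-benzothiazol-2-yl indistinguishable here, even though they differ in their ring atoms and the methoxy group. The remaining step, a 2.3-fold lower number from compound 2 to compound 4 (0.36 log units; beyond the scatter), changes the chain as well as the two-ring group, so it cannot be assigned to either alone.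

No measurement shown explains these differences. As far as these compounds go, it remains open how an amine or a simple phenyl in place of 1H-benzimidazol-2-yl on the sulfur would read in this assay.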